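This account rests on a few compounds, and the source may have more. Where it says the series, first, only, none or still open, it means among the compounds named here.

Of the compounds shown here, three built on one shared core have so far been tested in a functional assay on QGY7701 cells (Homo sapiens) for cytotoxicity, read by MTT assay, with a stated time of 48 h; a higher number here means a weaker inhibitor, a lower number a stronger inhibitor. Compound 1 `Cc1cccc(Cn2cc(COc3ccc4c(=O)ccoc4c3)nn2)c1` gives 22400 nM. Compound 2 `Cc1ccc(Cn2cc(COc3ccc4c(=O)ccoc4c3)nn2)cc1` gives 68500 nM in this assay, and the change of 4-methylphenyl in place of 3-methylphenyl on the saturated chain carbon bound to the aromatic nitrogen shows as a 3.1-fold higher number from compound 1 to compound 2 (0.49 log units; beyond the scatter). Compound 3 `O=c1ccoc2cc(OCc3cn(Cc4cccc(Cl)c4)nn3)ccc12` gives 28400 nM, which places it second highest of the three numbers: its nearest neighbour is compound 1, with a 1.3-fold higher number from compound 1 to compound 3 (0.10 log units; within the scatter), and its furthest is compound 2, with a 2.4-fold lower number from compound 2 to compound 3 (0.38 log units; beyond the scatter).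

Compound 4 `N#Cc1cccc(Cn2cc(COc3ccc4c(=O)ccoc4c3)nn2)c1` has not yet been measured in this assay. It differs from compound 3 by cyano in place of chloro on an aromatic carbon. Going by the values given here, no measured step swaps chloro for cyano, so the closest guide is the step from compound 1 to compound 3, where one group replaced another on the same aromatic carbon and the number stayed within the scatter; the two modest steps came only when the group changed place on the ring. Compound 4 is therefore expected to show a 1.1-fold higher number from compound 3 to compound 4 (0.02 log units; within the scatter), a step not beyond the scatter. The estimate for compound 4 in this assay is 30000 nM, with a range from 12000 nM to 75000 nM.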

Compound 4, half-maximal inhibitory concentration: 24400 nM
Compound 4: the middle estimate sits 1.2-fold (0.09 log units) above what was measured; low and high end bracket the measured number.
By their numbers in this assay, from the lowest: compounds 1, 4 and 3 (each within the scatter of the next); then compound 2.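

In this assay, the carbon meta to a large group has now carried methyl, chloro and cyano, and the third group separates from neither of the others (a 1.2-fold lower number from compound 3 to compound 4 (0.07 log units; within the scatter); a 1.1-fold higher number from compound 1 to compound 4 (0.04 log units; within the scatter)). Cyano brings two heavy atoms and a hydrogen-bond acceptor where chloro has one heavy atom and no acceptor, yet this difference leaves the number within the scatter, so the flat reading seen for methyl and chloro now extends to a third group. Going by these compounds alone, compound 2 with its 4-methylphenyl group remains the only compound set apart, now from the 3-cyanophenyl compound as well (a 2.8-fold lower number from compound 2 to compound 4 (0.45 log units; beyond the scatter)), but no measurement of another kind is available to explain this pattern.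

As far as these compounds go, what remains open is whether this position stays as flat with an amine, a carboxylic acid or a longer chain in place of these small groups. From the compounds shown here alone, it is also open whether chloro or cyano would follow methyl in the shift seen with 4-methylphenyl, as that group is the only one of its kind among the four compounds.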